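This account rests on a few compounds, and the source may have more. Where it says the series, first, only, none or still open, it means among the compounds named here.

Three compounds share one core and differ only in the aryl group on a carbon with a double bond to nitrogen. Compound 1 `C[C@H]1CC[C@@H]2[C@@H](OC(=O)[C@]23CC(c2c(Cl)cccc2Cl)=NO3)[C@]2(C)C(=O)C=C[C@@]12O` gives 2.67 in a physicochemical assay for lipophilicity (a lower number here means a more polar compound, a higher number a more lipophilic compound), compound 2 `C[C@H]1CC[C@@H]2[C@@H](OC(=O)[C@]23CC(c2ccccc2Br)=NO3)[C@]2(C)C(=O)C=C[C@@]12O` gives 2.22, and compound 3 `C[C@H]1CC[C@@H]2[C@@H](OC(=O)[C@]23CC(c2ccccc2F)=NO3)[C@]2(C)C(=O)C=C[C@@]12O` gives 1.58. Compound 2 stands second highest of the three: the steps of a number 0.45 log units lower from compound 1 to compound 2 (beyond the scatter) and a number 0.64 log units lower from compound 2 to compound 3 (beyond the scatter) both lie beyond the scatter, as does a number 1.09 log units lower from compound 1 to compound 3 (beyond the scatter).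

Compound 4 `Cc1ccc(C2=NO[C@]3(C2)C(=O)O[C@@H]2[C@H]3CC[C@H](C)[C@]3(O)C=CC(=O)[C@@]23C)cc1` is not yet measured; the change is 4-methylphenyl in place of 2-bromophenyl on a carbon with a double bond to nitrogen. Among the measured compounds shown here, no measured step exchanges a halogen for a methyl group; the nearest guide is the halogen swap from compound 2 to compound 3. A smaller downward step is therefore expected, a number 0.22 log units lower from compound 2 to compound 4 (within the scatter), and compound 4 is estimated at 2, within 1.6 to 2.4.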

Compound 4, partition coefficient: 1.86
The estimate for compound 4 lay 0.14 log units above the measured number; the range from low to high includes it.
By their numbers in this assay, from the lowest: compounds 3 and 4 (each within the scatter of the next); then compound 2; then compound 1.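

In this assay, among the compounds shown here, 4-methylphenyl is the first aryl group at this position without a halogen, and it still leaves the number inside the range set by the halogen-bearing rings: a number 0.36 log units lower from compound 2 to compound 4 (beyond the scatter), and a number 0.81 log units lower from compound 1 to compound 4 (beyond the scatter). Against the 2-fluorophenyl compound no separation appears, with a number 0.28 log units higher from compound 3 to compound 4 (within the scatter). No measurement shown here accounts for these steps. The compounds shown cannot separate the change of substituent from the change of its ring position in going from 2-bromophenyl to 4-methylphenyl. Going by these compounds, how an amine or a carboxylic acid on this aryl ring would read also remains open.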